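Return to a single five-membered ring on the core

The source may hold more compounds than are shown below. What is called first, only, known or untested is meant among the compounds shown, and "the series" means these compounds.

Among the measured compounds shown here, compound 2 `OC[C@H]1OC(n2cnc3c(-c4cc5ccccc5o4)ncnc32)[C@H](O)[C@@H]1O` gives the highest number of the two measured so far in a functional assay on CCRF-CEM cells (Homo sapiens) for inhibition; a higher number here means a weaker inhibitor, a lower number a stronger inhibitor: compound 2 gives 15000 nM, whereas compound 1 `Cn1cccc1-c1ncnc2c1ncn2C1O[C@H](CO)[C@@H](O)[C@H]1O` gives 2000 nM. For the measured compounds named here, the single measured step, a 7.5-fold higher number from compound 1 to compound 2 (0.88 log units; beyond the scatter), is the only guide available. Compound 3 `OC[C@H]1OC(n2cnc3c(-c4cc[nH]n4)ncnc32)[C@H](O)[C@@H]1O` is not yet measured; it differs from compound 2 as follows: 1H-pyrazol-3-yl in place of 1-benzofuran-2-yl on an aromatic carbon. Here 1-benzofuran-2-yl leaves and 1H-pyrazol-3-yl, a single five-membered aromatic ring like the 1-methyl-1H-pyrrol-2-yl of compound 1, enters, so the change runs opposite to the measured step. A lower number is therefore expected for compound 3, with a 4.3-fold lower number from compound 2 to compound 3 (0.63 log units; beyond the scatter) as the expected step. Going by the values given here, the group entering is not the one carried by compound 1, so the size of the step remains uncertain. Compound 3 is estimated at 3500 nM in this assay, within a range from 900 nM to 14000 nM.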

Compound 3, half-maximal inhibitory concentration: 750 nM
For compound 3 the middle estimate is 4.7-fold (0.67 log units) above the measured one, and the stated range ends above it.
By their numbers in this assay, from the lowest: compound 3; then compound 1; then compound 2.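

The position on the aromatic carbon of the shared core responds strongly to the size and make-up of the group it carries: a 20-fold lower number from compound 2 to compound 3 (1.30 log units; beyond the scatter) in this assay accompanies the exchange of the fused 1-benzofuran-2-yl for the single-ring 1H-pyrazol-3-yl. Single five-membered aromatic rings are also not interchangeable here, since a 2.7-fold lower number from compound 1 to compound 3 (0.43 log units; beyond the scatter) separates 1-methyl-1H-pyrrol-2-yl from 1H-pyrazol-3-yl, and of the three compounds the latter gives the lowest number. Nothing available accounts for either step.

Going by these compounds, whether an amine, a carboxylic acid or a longer chain on the 1H-pyrazol-3-yl ring would lower the number further remains open. So does the effect of a phenyl ring in this place, and whether this order of compounds holds outside these cells.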